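Dropping pyrrolidin-1-yl from the amide chain: Vero cell tolerance

A few compounds are considered here, and "the series" means these few. Any claim that something is new, unique, unknown or untested is made for them only; others in the source may bear on it.

Compound 1 `Cn1c(-c2ccc(NC(=O)CN3CCCC3)cc2)nc2cc(C(F)(F)F)ccc21`: in an ADME assay on Vero cells (Chlorocebus sabaeus) for cytotoxicity (a higher number here means that more compound is tolerated, a lower number that less compound is tolerated), compound 1 gives > 100000 nM, which is a limit of the assay.
Compound 2 `CC(=O)Nc1ccc(-c2nc3cc(C(F)(F)F)ccc3n2C)cc1`: in this assay compound 2 gives > 100000 nM, which is a limit of the assay.
Compound 3 `O=C(CN1CCCC1)Nc1ccc(-c2nc3ccccc3[nH]2)cc1`: in this assay compound 3 gives > 100000 nM, which is a limit of the assay.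

Compound 1 and compound 2 differ in one place: hydrogen in place of pyrrolidin-1-yl on a saturated chain carbon bound to a carbonyl carbon. Since both values are limits, the step that the two limits leave unreadable from compound 1 to compound 2 cannot be read. Compound 3 carries another core; how that core differs from the core of compound 1 is not broken down here. Compound 4 `CC(=O)Nc1ccc(-c2nc3ccccc3[nH]2)cc1` has not yet been measured in this assay. For the measured compounds named here, it differs from compound 3 by hydrogen in place of pyrrolidin-1-yl on a saturated chain carbon bound to a carbonyl carbon, the same change as the one from compound 1 to compound 2, made at the same place. Going by the values given here, every measured value so far sits at the limit (the limit of > 100000 nM in this assay, at which 3 of the 3 values shown sit). On that basis the step that the limit leaves unreadable from compound 3 to compound 4 is expected to be small. This expectation rests on the shared limit of > 100000 nM in this assay, at which 3 of the 3 values shown sit, reached by compound 1, compound 2 and compound 3. Compound 4 is therefore estimated at 150000 nM in this assay, most likely again reported only as a limit.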

Compound 4, half-maximal cytotoxic concentration: > 100000 nM
Compound 4: only a limit was reported (the forecaster's own chance of this, stated with the estimate: 85%); the middle value lies beyond the limit too.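

In this assay compound 4 gives > 100000 nM, which is a limit of the assay. For the compounds shown here, compound 3 also stands at a limit, so no step between compound 3 and compound 4 can be read. Still open is whether swapping pyrrolidin-1-yl for hydrogen changes tolerance at all, because every value stops at the same point: the limit of > 100000 nM in this assay, at which 4 of the 4 values shown sit.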